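Chain substituent variation on the piperidine amide series

The compounds below may be only part of what the source reports. "The series", "measured", "known", "first", "only" and "open" are said of these compounds alone.

Measured compounds:
- compound 1 `Cn1ncc(Cl)c1-c1cc(C(=O)N[C@@H]2CN[C@H](CCn3cncn3)C[C@H]2c2ccc(Cl)c(Cl)c2)oc1Cl`: 60 nM
- compound 2 `CN(C)CC[C@@H]1C[C@@H](c2ccc(Cl)c(Cl)c2)[C@H](NC(=O)c2cc(-c3c(Cl)cnn3C)c(Cl)o2)CN1`: 1930 nM

In a functional assay on LNCaP cells (Homo sapiens) for antiproliferative activity (on this read-out lower numbers stand for stronger inhibition and higher numbers for weaker inhibition), compound 1 gives 60 nM and stands lowest of the two numbers; compound 2 gives 1930 nM. Going by the values given here, the one recorded step at this position is a 32-fold higher number from compound 1 to compound 2 (1.51 log units; beyond the scatter), a large step away from compound 1. Compound 3 `Cn1ncc(Cl)c1-c1cc(C(=O)N[C@@H]2CN[C@H](CC(=O)NC3CCC3)C[C@H]2c2ccc(Cl)c(Cl)c2)oc1Cl` has not yet been measured in this assay. It differs from compound 1 by cyclobutylcarbamoyl in place of (1H-1,2,4-triazol-1-yl)methyl on a saturated chain carbon bound to a saturated ring carbon. Among the compounds with values here, no measured step covers this particular change; the only pair that bears on it is the step to compound 2, which shows that replacing the group on this chain carbon can move the number a long way, though the entering group there is a different one. Within the data shown here, compound 3 is therefore expected to give a somewhat higher number, a 4.2-fold higher number from compound 1 to compound 3 (0.62 log units; beyond the scatter), with a wide range because a 32-fold higher number from compound 1 to compound 2 (1.51 log units; beyond the scatter) is the sole guide. The estimate for compound 3 is 250 nM, between 60 nM and 1200 nM.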

Compound 3, half-maximal inhibitory concentration: 80 nM
The estimate for compound 3 lay 3.1-fold (0.49 log units) above the measured number; the measured number falls inside the stated range.
By their numbers in this assay, from the lowest: compounds 1 and 3 (each within the scatter of the next); then compound 2.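

In this assay, cyclobutylcarbamoyl in place of (1H-1,2,4-triazol-1-yl)methyl gives a 1.3-fold higher number from compound 1 to compound 3 (0.12 log units; within the scatter), so among these compounds the one five-membered aromatic ring is not needed on this saturated chain carbon to keep the number low. The other comparison gives a 24-fold lower number from compound 2 to compound 3 (1.38 log units; beyond the scatter), so the large step seen earlier does not follow from every replacement at this place; of the three compounds, only compound 2, with (dimethylamino)methyl, stands apart. Nothing at hand bears on the reason for these steps.

Open, going by these compounds, is whether a primary amide, a carboxylic acid or a longer chain on this carbon would stay with compound 1 and compound 3 or lie nearer compound 2. Also open, on these data alone, is whether the step to compound 2 belongs to dimethylamino alone or would recur with another amine, such as pyrrolidine.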